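The source may hold more compounds than are shown below. What is called first, only, known or untested is meant among the compounds shown, and "the series" means these compounds.

Compound 1 `Nc1cc(N)c2nc(-c3ccccc3)c(Oc3ccc(Cl)c(Cl)c3)nc2c1`: < 100000 nM
Compound 2 `Nc1cc(N)c2nc(-c3ccccc3)c(NCc3ccc(Cl)c(Cl)c3)nc2c1`: < 100000 nM
Compound 3 `COc1ccc(CNc2nc3cc(N)cc(N)c3nc2-c2ccccc2)cc1OC`: < 100000 nM

Of the compounds shown here, three with a shared core have been tested in a functional assay on SR cells (Homo sapiens) for inhibition, read by sulforhodamine B assay, with a stated time of 48 h; a higher number here means that more compound is tolerated, a lower number that less compound is tolerated. For compound 1 the value < 100000 nM is a limit of the assay, not a number. For compound 2 the value < 100000 nM is likewise a limit. For compound 3 the value < 100000 nM is also a limit. The step that the two limits leave unreadable from compound 2 to compound 3 therefore cannot be read, and all three values sit at the same point, as summed up in the limit of < 100000 nM in this assay, at which 3 of the 3 values shown sit. Compound 4 `Nc1cc(N)c2nc(-c3ccccc3)c(NCc3ccc(F)cc3)nc2c1` differs from compound 3 by 4-fluorophenyl in place of 3,4-dimethoxyphenyl on a saturated chain carbon bound to a nitrogen on an aromatic ring. Among the measured compounds shown here, no measured step reads on this change. Compound 4 is expected to stay at the same limit, an expected step that the limit leaves unreadable from compound 3 to compound 4. The estimate for compound 4 is 30000 nM, ranging from 5000 nM to 100000 nM.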

Compound 4, concentration lethal to 50% of the cells: < 100000 nM
Compound 4: a limit, no number (the forecaster's own chance of this, stated with the estimate: 80%); the middle value lies beyond the limit too.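

Among the compounds shown here, the result for compound 4 is also a limit and not a number, so no step linking it to compound 1, compound 2 or compound 3 can be read, and all four share one point: the limit of < 100000 nM in this assay, at which 4 of the 4 values shown sit. From the compounds shown here alone, whether these compounds differ at all in this assay, and by how much, stays open.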